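The compounds below may be only part of what the source reports. "The series", "measured", "known", "first", "only" and "open" are said of these compounds alone.

Working notes on the series.

Compound 1 `O=C(NCN1CCC(c2cccc[n+]2[O-])CC1)c1cnccc1Cl` is the weaker of the two measured entries: in a functional assay on HEK293 cells for agonist activity at D(4) dopamine receptor (Homo sapiens), read by FLIPR (a higher number here means that more compound is needed for the effect, a lower number that less compound is needed), compound 1 gives 1290 nM. Among the compounds with values here, the only other measured entry is compound 2 `Cc1cccc(Cl)c1NC(=O)CN1CCC(c2ccccn2)CC1`, which in this assay gives 60 nM; the two structures differ in more than one place, so no single step connects them, and the gap between them, beyond the scatter, simply shows that the measured range in this assay already spans a wide band.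

Compound 3 `N#Cc1cccc(C(=O)NCN2CCC(c3cccc[n+]3[O-])CC2)c1` keeps the core of compound 1 and differs only in the group carried by the carbonyl carbon: 3-cyanophenyl in place of 4-chloropyridin-3-yl on a carbonyl carbon. Nothing measured separates the effect of this exchange from the rest of the molecule, so the direction is not fixed by the data. The expectation is a step from a 1.3-fold lower number from compound 1 to compound 3 (0.11 log units; within the scatter) that stays within or close to the usual scatter, with no strong reason to place it either way. For compound 3 the estimate in this assay is therefore 1000 nM, with a range from 250 nM to 4000 nM.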

Compound 3, half-maximal effective concentration: 840 nM
Beside the measured number, compound 3's estimate is 1.2-fold (0.08 log units) above it; measured number inside the range.
By their numbers in this assay, from the lowest: compound 2; then compounds 3 and 1 (each within the scatter of the next).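

Within the data shown here, at the group on the carbonyl carbon, this assay gives the first comparison that differs in one place: a 1.5-fold lower number from compound 1 to compound 3 (0.19 log units; within the scatter). With 3-cyanophenyl in place of 4-chloropyridin-3-yl, a ring of carbon only carrying a triple bond takes the place of a ring with one hetero atom carrying chlorine, yet the two compounds cannot be told apart in this read-out, so this exchange leaves the number within the scatter on the core of compound 1. No supporting data bear on this outcome, and it stays a plain observation.

Still open, as far as these compounds go, is whether a group of another kind on the carbonyl carbon, such as an open-chain aliphatic amine or a carboxylic acid on the aromatic ring, would move the number beyond the scatter, since the two groups compared here are both six-membered aromatic rings. Also open, from the compounds shown here alone, is whether 3-cyanophenyl and 4-chloropyridin-3-yl would stay equally close on a different core, as this single pair shares one core.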